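The source may hold more compounds than are shown below. What is called first, only, known or untested is meant among the compounds shown, and "the series" means these compounds.

Series notes. Compound 1 `COc1cc2c(cc1OC)C(=O)C(C(=O)Nc1ccccc1)C2` is the unsubstituted parent; compound 2 `COc1cc2c(cc1OC)C(=O)C(C(=O)Nc1ccc(F)cc1)C2` and compound 3 `COc1cc2c(cc1OC)C(=O)C(C(=O)Nc1ccc(Cl)cc1)C2` carry fluoro and chloro on an aromatic carbon of the amide-side ring. In a physicochemical assay, with a stated time of 30 min (on this read-out higher numbers stand for weaker inhibition and lower numbers for stronger inhibition), compound 1 gives 61.3 ug/mL, compound 2 gives 55 ug/mL and compound 3 gives 56.8 ug/mL. The steps of a 1.1-fold lower number from compound 1 to compound 2 (0.05 log units; within the scatter) and a 1.1-fold lower number from compound 1 to compound 3 (0.03 log units; within the scatter) both lie within the scatter, as does a 1.0-fold higher number from compound 2 to compound 3 (0.01 log units; within the scatter); the three numbers cannot be told apart, and compound 2 sits with the other two without separation from either. Compound 4 `COc1cc2c(cc1OC)C(=O)C(C(=O)Nc1ccccc1F)C2` differs from compound 2 by 2-fluorophenyl in place of 4-fluorophenyl on an amide-type nitrogen. Among the compounds with values here, no measured step exchanges 4-fluorophenyl for 2-fluorophenyl, so the only bearing the data have is indirect: neither adding a halogen nor swapping one has moved the read-out beyond the scatter. In this assay the step expected is a 1.0-fold higher number from compound 2 to compound 4 (0.02 log units; within the scatter), with no direction asserted. Compound 4 is estimated at 57 ug/mL, in a range from 35 ug/mL to 95 ug/mL.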

Compound 4, half-maximal inhibitory concentration: 75.7 ug/mL
Compound 4: middle estimate off by 1.3-fold (0.12 log units), on the low side; the measured number falls inside the stated range.
By their numbers in this assay, from the lowest: compounds 2, 3, 1 and 4 (each within the scatter of the next).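

Shifting the fluoro from 4-fluorophenyl to 2-fluorophenyl on the amide-type nitrogen tests where the halogen sits rather than whether one is present, and in this assay it gives a 1.4-fold higher number from compound 2 to compound 4 (0.14 log units; within the scatter) and so stays inside the scatter. The comparisons with the other two neighbours read the same, with a 1.3-fold higher number from compound 3 to compound 4 (0.12 log units; within the scatter) and a 1.2-fold higher number from compound 1 to compound 4 (0.09 log units; within the scatter) leaving 2-fluorophenyl inseparable from 4-chlorophenyl and from the unsubstituted phenyl at this nitrogen. Nothing available bears on what lies behind these numbers.

Still open, from the compounds shown here alone, is whether any group on this nitrogen can move the read-out beyond the scatter, as only phenyl and its halogen forms appear here. A carboxylic acid or an amine on that ring, or a longer chain in place of it, would be a wider change than any shown.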